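A few compounds are considered here, and "the series" means these few. Any claim that something is new, unique, unknown or untested is made for them only; others in the source may bear on it.

Measured compounds:
Compound 1, `COc1cc(-c2nn(-c3cccc(NC(=O)Nc4ccc(Cl)c(Cl)c4)c3)cc2-c2ccncc2)ccc1Cl`, in a functional assay on HOP-92 cells (Homo sapiens) for inhibition, read by sulforhodamine B assay, with a stated time of 48 h (a lower number here means a stronger inhibitor of growth, a higher number a weaker inhibitor of growth), gives 1470 nM.
Compound 2, `O=C(Nc1cccc(-n2cc(-c3ccncc3)c(-c3ccc(Cl)c(O)c3)n2)c1)Nc1ccc(Cl)c(Cl)c1`, in this assay gives 1910 nM.
Compound 3, `COc1cc(-c2nn(-c3cccc(NC(=O)Nc4ccc(Cl)c(C(F)(F)F)c4)c3)cc2-c2ccncc2)ccc1Cl`, in this assay gives 1480 nM.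

The three values lie close together. Compound 2 arises from compound 1 by hydrogen in place of methyl on an oxygen on an aromatic ring, a change that gave a 1.3-fold higher number from compound 1 to compound 2 (0.11 log units; within the scatter). The cores of compound 1 and compound 3 differ by trifluoromethyl in place of chloro on an aromatic carbon, which gave a 1.0-fold higher number from compound 1 to compound 3 (0.00 log units; within the scatter).

Compound 4, `O=C(Nc1cccc(-n2cc(-c3ccncc3)c(-c3ccc(Cl)c(O)c3)n2)c1)Nc1ccc(Cl)c(C(F)(F)F)c1`, has not been measured in this assay. It arises from compound 3 by hydrogen in place of methyl on an oxygen on an aromatic ring, the same change at the same place as that from compound 1 to compound 2. The expected step is a 1.3-fold higher number from compound 3 to compound 4 (0.11 log units; within the scatter) because the measured pair gave a 1.3-fold higher number from compound 1 to compound 2 (0.11 log units; within the scatter). Compound 4 is therefore estimated at 1900 nM, likely between 1100 nM and 3500 nM.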

Compound 4, concentration for total growth inhibition: 1460 nM
Estimate against measurement, compound 4: 1.3-fold (0.11 log units) above; measured number inside the range.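

In this assay, hydrogen in place of methyl on the oxygen gave a 1.0-fold lower number from compound 3 to compound 4 (0.01 log units; within the scatter), and this agrees with the earlier step on the other core: the same change on two cores in this assay, a 1.3-fold higher number (0.11 log units; within the scatter) from compound 1 to compound 2 and a 1.0-fold lower number (0.01 log units; within the scatter) from compound 3 to compound 4, 1.3-fold (0.12 log units) apart, within the scatter of two such steps. Trifluoromethyl in place of chloro gave a 1.3-fold lower number from compound 2 to compound 4 (0.12 log units; within the scatter), and this agrees in the same way: the same change on two cores in this assay, a 1.0-fold higher number (0.00 log units; within the scatter) from compound 1 to compound 3 and a 1.3-fold lower number (0.12 log units; within the scatter) from compound 2 to compound 4, 1.3-fold (0.12 log units) apart, within the scatter of two such steps. Going by these compounds alone, each change therefore left the number within the scatter on both cores, but this shows only that two small steps agree, not that a step of real size would carry from one core to another.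

The compounds shown leave open how an amine or a carboxylic acid in place of the methoxy would read on these cores. They also leave open whether a larger step, if one exists, would hold across cores.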